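The compounds below may be only part of what the source reports. "The series", "measured", "known", "first", "only" and "open" are said of these compounds alone.

The account follows the change from compound 2 to compound 3. Compound 2, `COc1cc(-c2nn(-c3cccc(NC(=O)Nc4ccc(Cl)c(C(F)(F)F)c4)c3)cc2-c2ccncc2)ccc1Cl`, is known only by a limit: in a functional assay on MOLT-4 cells (Homo sapiens) for inhibition, read by sulforhodamine B assay, with a stated time of 48 h (a higher number here means that more compound is tolerated, a lower number that less compound is tolerated), compound 2 gives > 32500 nM, which is a limit of the assay and not a number. Compound 1, `COc1cc(-c2nn(-c3cccc(NC(=O)Nc4cccc(C(F)(F)F)c4)c3)cc2-c2ccncc2)ccc1Cl`, also sits at a limit, giving > 50000 nM in this assay. The step that the two limits leave unreadable from compound 1 to compound 2 therefore cannot be read, since one value sits at the limit of > 32500 nM in this assay, at which 1 of the 2 values shown sits, and the other at the limit of > 50000 nM in this assay, at which 1 of the 2 values shown sits. Compound 3, `COc1cc(-c2nn(-c3cccc(NC(=O)c4ccccc4)c3)cc2-c2ccncc2)ccc1Cl`, differs from compound 2 by phenyl in place of (4-chloro-3-(trifluoromethyl)phenyl)amino on a carbonyl carbon. Within the data shown here, no measured step bears on this change, so compound 3 is expected to show no step beyond the scatter, a step that the limit leaves unreadable from compound 2 to compound 3. Compound 3 is thus estimated at 50000 nM in this assay, in a range from 15000 nM to 120000 nM.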

Compound 3, concentration lethal to 50% of the cells: > 100000 nM
Compound 3: only a limit was reported (the forecaster's own chance of this, stated with the estimate: 80%); middle value at least 2.0-fold (0.30 log units) from the limit.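

In this assay compound 3 gives > 100000 nM, a limit of the assay and not a number, so the steps to it from compound 1 and compound 2 cannot be read. The compounds shown leave open whether phenyl on the carbonyl carbon changes the read-out at all.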